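Changing the Ester Group on a Shared Core

The source may report more compounds than this note shows. Statements on the series, on what has been measured and on what is new or still open speak of the compounds shown alone.

Compound 1 `CCCCC1=C(C(=O)OCC)C(c2cccc([N+](=O)[O-])c2)C(C(=O)OCC)=C(C)N1` gives 20 nM in a functional assay on HEK293 cells for antagonist activity at Voltage-dependent L-type calcium channel subunit alpha-1D (Rattus norvegicus), read by FLIPR; on this read-out higher numbers stand for weaker inhibition and lower numbers for stronger inhibition.
Compound 2 `CCOC(=O)C1=C(C)NC(CCl)=C(C(=O)OCC)C1c1cccc([N+](=O)[O-])c1` gives 53 nM.
Compound 3 `C=C(C)CCOC(=O)C1=C(C)NC(C)=C(C(=O)OC)C1c1cccc([N+](=O)[O-])c1` gives 47 nM.

Compound 3 stands second highest of the three numbers; compound 2 lies within the scatter of it, while compound 1 gives a lower number, beyond the scatter. Compound 4 `COC(=O)C1=C(C)NC(C)=C(C(=O)OCc2ccc(OC)c(OC)c2)C1c1cccc([N+](=O)[O-])c1` differs from compound 3 by 3,4-dimethoxyphenyl in place of 2-methylprop-2-en-1-yl on a saturated chain carbon bound to an oxygen next to a carbonyl group. Going by the values given here, the only measured step, a 2.7-fold higher number from compound 1 to compound 2 (0.42 log units; beyond the scatter), concerns a different position and so does not bear directly on this change. Among the compounds with values here, with no step at this ester position, the expected change a 1.1-fold higher number from compound 3 to compound 4 (0.03 log units; within the scatter) is set close to none, with a wide range. Compound 4 is therefore estimated at 50 nM, between 15 nM and 170 nM.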

Compound 4, half-maximal inhibitory concentration: 117 nM
Compound 4: middle estimate off by 2.3-fold (0.37 log units), on the low side, and the stated range covers the measured number.
By their numbers in this assay, from the lowest: compound 1; then compounds 3 and 2 (each within the scatter of the next); then compound 4.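

In this assay, 3,4-dimethoxyphenyl in place of 2-methylprop-2-en-1-yl on a saturated chain carbon bound to an oxygen next to a carbonyl group gives a 2.5-fold higher number from compound 3 to compound 4 (0.40 log units; beyond the scatter) as the first step read at this ester position. Inhibition is therefore weaker with this aromatic group, so what the ester carries here does matter. No measurement given here accounts for this step.

Still open, from the compounds shown here alone, is whether a plain benzyl without the methoxy groups, or an ester chain ending in an amine, would read nearer compound 3 or compound 4.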